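From 3,4-dicyanophenyl to Phenyl: A Tolerance Estimate

The compounds below may be only part of what the source reports. "The series", "measured", "known", "first", "only" and "open" are said of these compounds alone.

Cell-toxicity measurements show how much compound living cells can withstand, which makes them a useful safety check. In a toxicity assay on MT4 cells (Homo sapiens) for cytotoxicity, read by MTT assay (a lower number here means that less compound is tolerated, a higher number that more compound is tolerated), compound 1 (`Cc1cc(-c2ccccc2)cc(C)c1Oc1cc(N)nc(Nc2ccc(C#N)cc2)n1`) gives 25600 nM. Compound 2 (`Cc1cc(-c2ccc(C#N)c(C#N)c2)ccc1Oc1cc(N)nc(Nc2ccc(C#N)cc2)n1`) gives 76700 nM, the higher of the two numbers, and the gap between them lies beyond the usual scatter.

Compound 3 (`Cc1cc(-c2ccccc2)ccc1Oc1cc(N)nc(Nc2ccc(C#N)cc2)n1`) has not yet been measured. Its structure has phenyl in place of 3,4-dicyanophenyl on an aromatic carbon of compound 2 (phenyl in place of 3,4-dicyanophenyl on an aromatic carbon). Within the data shown here, no measured pair shows this swap on its own, so the expectation rests on thin evidence. The closest guide is compound 1, which also carries a phenyl group and gives 25600 nM in this assay.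

A move towards that lower number therefore seems likely, meaning that less compound would be tolerated. The expected change is a 2.6-fold lower number from compound 2 to compound 3 (0.41 log units; beyond the scatter), and this estimate is uncertain. For compound 3, the estimated value is 30000 nM, with an expected range from 11000 nM to 80000 nM.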

Compound 3, half-maximal cytotoxic concentration: 20000 nM
Estimate against measurement, compound 3: 1.5-fold (0.18 log units) above; low and high end bracket the measured number.
By their numbers in this assay, from the lowest: compounds 3 and 1 (each within the scatter of the next); then compound 2.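

Measured in this assay with nothing else altered, phenyl in place of 3,4-dicyanophenyl gives a 3.8-fold lower number from compound 2 to compound 3 (0.58 log units; beyond the scatter) and so the group on this aromatic carbon does matter: less compound is tolerated with plain phenyl than with the ring carrying two nitriles. The earlier pair of compounds could not show this, since compound 1 and compound 2 differ in more than one place. Hydrogen in place of methyl gives a 1.3-fold lower number from compound 1 to compound 3 (0.11 log units; within the scatter) and this step lies within the scatter, so in this pair the methyl group makes no difference that can be told apart from repeat variation. No measurement available here speaks to what lies behind either step.

As far as these compounds go, it remains open whether a phenyl ring bearing a single nitrile would sit nearer compound 2 or compound 3, and how an amine or a carboxylic acid on that ring would read. From the compounds shown here alone, the methyl step also rests on one pair with phenyl in place, so whether it would stay as small alongside 3,4-dicyanophenyl is unknown.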